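Chloro for hydrogen on the phenyl of compound 3

This account rests on a few compounds, and the source may have more. Where it says the series, first, only, none or still open, it means among the compounds named here.

Compound 3 `CC(C(=O)N1CCN(c2ccccc2)CC1)N1C(=O)CC(C)(C)C1=O` in a functional assay on the whole organism (strain Swiss) with Mus musculus as the target, in the maximal electroshock model, with a stated time of 0.25 h (on this read-out higher numbers stand for an effect only at larger amounts of compound and lower numbers for an effect already at smaller amounts), reaches only the limit of the measurement, > 130 mg/kg, so it stands with no number of its own. Compound 2 `CC(C(=O)N1CCN(c2ccccc2C(F)(F)F)CC1)N1C(=O)CC(C)(C)C1=O` likewise gives only the limit > 130 mg/kg. Hence the step that the two limits leave unreadable from compound 2 to compound 3 cannot be sized, as both ends sit at the limit (the limit of > 130 mg/kg in this assay, at which 2 of the 3 values shown sit). Compound 1 `CC1CC(=O)N(C(C)C(=O)N2CCN(c3cccc(Cl)c3)CC2)C1=O`, which carries a different core, gives 89.7 mg/kg in this assay.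

The change from compound 3 to compound 4 `CC(C(=O)N1CCN(c2cccc(Cl)c2)CC1)N1C(=O)CC(C)(C)C1=O` is chloro in place of hydrogen on an aromatic carbon, placed on an aromatic carbon of a six-membered aromatic ring of carbon only, meta to a large group; one bond further out it reads phenyl to 3-chlorophenyl. Going by the values given here, no measured step follows this exact change on the shared core of compound 3: the only readable comparison is that compound 1, which bears the same 3-chlorophenyl on another core, returns a number rather than a limit. That is an indirect hint and nothing more.

The expectation for compound 4 is therefore a value near the limit, possibly just inside it, with the step of an at least 1.1-fold lower number from compound 3 to compound 4 (0.05 log units; that floor lies within the scatter) estimated from compound 3 at the limit. Compound 4 is estimated at 115 mg/kg in this assay, between 60 mg/kg and 220 mg/kg.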

Compound 4, dose for half-maximal effect: 120 mg/kg
Compound 4: middle estimate off by 1.0-fold (0.02 log units), on the low side; low and high end bracket the measured number.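

Chloro in place of hydrogen on an aromatic carbon, meta to a large group, gives the shared core of compound 4 a number in this assay, but the step is only an at least 1.0-fold lower number from compound 3 to compound 4 (0.03 log units; that floor lies within the scatter), so this change is not shown to do more than the scatter allows. With the 3-chlorophenyl held constant, the step for methyl in place of hydrogen on a saturated ring carbon is a 1.3-fold higher number from compound 1 to compound 4 (0.13 log units; within the scatter), so the data do not separate these two cores. The step between compound 2 and compound 3 still cannot be read, and neither compound has a number of its own: the limit of > 130 mg/kg in this assay, at which 2 of the 4 values shown sit.

From the compounds shown here alone, the true size of the change from phenyl to 3-chlorophenyl remains open, as the step has only a floor and could be larger. Also open, going by these compounds, is what fluoro, bromo, methoxy or a nitrile would give on the same aromatic carbon of the shared core, and whether any of them would return a number clearly apart from that of compound 4.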